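A few compounds are considered here, and "the series" means these few. Any claim that something is new, unique, unknown or untested is made for them only; others in the source may bear on it.

In an ADME assay on Vero cells (Chlorocebus sabaeus) for cytotoxicity, read by polymerase chain reaction, with a stated time of 18 h (a lower number here means that less compound is tolerated, a higher number that more compound is tolerated), the three measured compounds gave these numbers:

Compound 1, `O=c1cc(CSc2nc3ccccc3c(=O)[nH]2)c2ccc(OS(=O)(=O)c3ccc(F)cc3)cc2o1`: 30000 nM
Compound 2, `O=c1cc(CSc2nc3ccccc3c(=O)[nH]2)c2ccc(OS(=O)(=O)c3ccccc3[N+](=O)[O-])cc2o1`: 144000 nM
Compound 3, `O=C1CCN=C(SCc2cc(=O)oc3cc(OS(=O)(=O)c4ccc(F)cc4)ccc23)N1`: 111000 nM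

Compound 2 is compound 1 with one group swapped: 2-nitrophenyl in place of 4-fluorophenyl on a sulfonyl sulfur. That swap gave a 4.8-fold higher number from compound 1 to compound 2 (0.68 log units; beyond the scatter). Compound 3 keeps the sulfonyl side of compound 1 but carries a different core; the difference between the two cores is a group of 7 heavy atoms (4 carbon, 2 nitrogen, 1 oxygen; one six-membered non-aromatic ring with 2 hetero atoms) in place of a group of 11 heavy atoms (8 carbon, 2 nitrogen, 1 oxygen; one six-membered aromatic ring of carbon only, one six-membered aromatic ring with 2 hetero atoms), on a sulfur, and it gave a 3.7-fold higher number from compound 1 to compound 3 (0.57 log units; beyond the scatter). Compound 2 and compound 3 lie within the usual scatter of each other, so nothing separates them.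

Compound 4, `O=C1CCN=C(SCc2cc(=O)oc3cc(OS(=O)(=O)c4ccccc4[N+](=O)[O-])ccc23)N1`, has not yet been measured in this assay. It stands to compound 3 as compound 2 stands to compound 1: the difference is 2-nitrophenyl in place of 4-fluorophenyl on a sulfonyl sulfur, and the place, a sulfonyl sulfur whose other neighbours are oxygen on an aromatic ring, reads the same in both pairs, so this is the same change, seen twice among these four compounds. Among the measured compounds shown here, only one measured instance of it exists, which is a thin basis. The step from compound 3 to compound 4 in this assay is expected to be a 2.7-fold higher number from compound 3 to compound 4 (0.43 log units; beyond the scatter), somewhat smaller than the earlier step. This rests on the fact that the earlier instance gave a 4.8-fold higher number from compound 1 to compound 2 (0.68 log units; beyond the scatter) from a lower starting number, whereas compound 3 starts higher. Compound 4 is therefore estimated at 300000 nM, with a likely range from 110000 nM to 800000 nM.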

Compound 4, half-maximal cytotoxic concentration: 75200 nM
Compound 4: middle estimate off by 4.0-fold (0.60 log units), on the high side; measured number outside the range, below it.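

In this assay, 2-nitrophenyl in place of 4-fluorophenyl on a sulfonyl sulfur does not carry over from the core of compound 1 to the core of compound 3, as the new step, a 1.5-fold lower number from compound 3 to compound 4 (0.17 log units; within the scatter), stands far from the earlier one: the same change on two cores in this assay, a 4.8-fold higher number (0.68 log units; beyond the scatter) from compound 1 to compound 2 and a 1.5-fold lower number (0.17 log units; within the scatter) from compound 3 to compound 4, 7.1-fold (0.85 log units) apart, beyond the scatter of two such steps. The exchange of cores reads the same way, this time with 2-nitrophenyl on the sulfonyl sulfur, where the new step is a 1.9-fold lower number from compound 2 to compound 4 (0.28 log units; within the scatter): the same change on two cores in this assay, a 3.7-fold higher number (0.57 log units; beyond the scatter) from compound 1 to compound 3 and a 1.9-fold lower number (0.28 log units; within the scatter) from compound 2 to compound 4, 7.1-fold (0.85 log units) apart, beyond the scatter of two such steps. Read together, either change raises the number from compound 1, while making the second change on top adds nothing beyond the scatter, but these two comparisons rest on the same four compounds, so they are one finding seen from two sides and do not show why the two changes fail to add up.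

The compounds shown leave open whether compound 1 is a lone exception or whether other groups on the sulfonyl sulfur, such as a plain methyl or a 4-methoxyphenyl, would also depend on the core. They also leave open how a simple open chain on the sulfur, such as an aminoethyl group, would behave in place of either core.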